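Pentyl for aryl on the triazole: working notes

The compounds below may be only part of what the source reports. "The series", "measured", "known", "first", "only" and "open" are said of these compounds alone.

In a functional assay on A549 cells (Homo sapiens) for antiproliferative activity, read by MTT assay (a higher number here means a weaker inhibitor, a lower number a stronger inhibitor), the measured compounds read as follows:
- Compound 1 `COc1ccc(-n2cc(COc3ccc(/C=C/C(=O)c4cc5c(cc4O)OC(C)(C)CC5)cc3)nn2)c([N+](=O)[O-])c1` gives 99500 nM
- Compound 2 `CC(=O)c1ccc(-n2cc(COc3ccc(/C=C/C(=O)c4ccc5c(c4O)CCC(C)(C)O5)cc3)nn2)cc1` gives 149000 nM
- Compound 3 `Cc1ccc(-n2cc(COc3ccc(/C=C/C(=O)c4ccc5c(c4O)CCC(C)(C)O5)cc3)nn2)cc1Br` gives "not active" (no number reported)

Compound 1 and compound 2 lie within the scatter of each other, so neither can be ranked ahead. Compound 3 has no number to place beside them. Among the measured compounds shown here, these three compounds differ from one another in more than one place, so no single-change step has been measured.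

The next compound is compound 4 `CCCCCn1cc(COc2ccc(/C=C/C(=O)c3cc4c(cc3O)OC(C)(C)CC4)cc2)nn1`, which keeps the core of compound 1. The change is pentyl in place of 4-methoxy-2-nitrophenyl on an aromatic nitrogen of a five-membered aromatic ring (pentyl in place of 4-methoxy-2-nitrophenyl on an aromatic nitrogen). For the measured compounds named here, no measured compound carries an open chain at this nitrogen, so the data give no direct guide to this change.

In this assay no step beyond the scatter is expected, and neither direction is favoured. The expected 1.2-fold lower number from compound 1 to compound 4 (0.09 log units; within the scatter) serves as the working figure. The reading for compound 3 ("not active" (no number reported)) leaves open a result without a number. The estimate for compound 4 is 80000 nM, with an expected range from 25000 nM to 200000 nM in this series.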

Compound 4, half-maximal inhibitory concentration: 91300 nM
For compound 4 the middle estimate is 1.1-fold (0.06 log units) below the measured one; the measured number falls inside the stated range.
By their numbers in this assay, from the lowest: compounds 4, 1 and 2 (each within the scatter of the next).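

In this assay, among the compounds shown here, the exchange of 4-methoxy-2-nitrophenyl for pentyl on the aromatic nitrogen of the triazole gives a 1.1-fold lower number from compound 1 to compound 4 (0.04 log units; within the scatter) on the shared core, and this is the first single-change step. An aryl group at this nitrogen is therefore not required to keep the number in the range of compound 1: pentyl has no ring and no hydrogen-bond acceptors, yet the step stays within the scatter, so on this one pair, neither the aromatic ring nor the nitro and methoxy groups of the leaving substituent can be tied to a measurable difference. No measurement available here accounts for this outcome.

A single open chain cannot show whether the nitrogen accepts any substituent or only groups like these two, so a shorter chain such as propyl, a longer chain such as decyl, or a chain ending in an amine or a carboxylic acid could still separate from compound 4 beyond the scatter. For the compounds shown here, it also remains open whether pentyl in place of an aryl group reads the same way on the core of compound 2, where the step has no measured pair.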